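This account rests on a few compounds, and the source may have more. Where it says the series, first, only, none or still open, it means among the compounds named here.

Measured in a functional assay on MCF7 cells (Homo sapiens) for antiproliferative activity, read by sulforhodamine B assay, with a stated time of 48 h; a higher number here means a weaker inhibitor, a lower number a stronger inhibitor:
- compound 1 `O=C1NCCN1c1ccc(S(=O)(=O)Nc2ccc(I)cc2)cc1`: 600 nM
- compound 2 `O=C1NCCN1c1ccc(S(=O)(=O)Nc2ccccc2)cc1`: 470 nM

Among the compounds with values here, compound 2, at 470 nM, cannot be separated from the only other measured compound, as the step reads a 1.3-fold lower number from compound 1 to compound 2 (0.11 log units; within the scatter). Compound 3 `CCc1cccc(NS(=O)(=O)c2ccc(N3CCNC3=O)cc2)c1` places ethyl in place of hydrogen on an aromatic carbon, meta to a large group: ethyl in place of hydrogen on an aromatic carbon. Within the data shown here, the sole measured step bearing on this exchanges iodo rather than ethyl, and it stayed within the scatter, so no size or direction of change beyond the scatter is expected in this assay. The expected step is a 1.1-fold lower number from compound 2 to compound 3 (0.05 log units; within the scatter). For compound 3 the estimated value is 420 nM, with an expected range of 130 nM to 1300 nM.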

Compound 3, half-maximal inhibitory concentration: 130 nM
Compound 3: middle estimate off by 3.2-fold (0.51 log units), on the high side; low and high end bracket the measured number.
By their numbers in this assay, from the lowest: compound 3; then compounds 2 and 1 (each within the scatter of the next).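

On the phenyl group on the sulfonamide nitrogen, ethyl in place of hydrogen, meta to a large group, gave a 3.6-fold lower number from compound 2 to compound 3 (0.56 log units; beyond the scatter) in this assay and so moved the number beyond the scatter, which the iodo exchange had not done. Against the 4-iodophenyl group, the 3-ethylphenyl group gave a 4.6-fold lower number from compound 1 to compound 3 (0.66 log units; beyond the scatter) as well. Nothing measured here accounts for this change. As far as these compounds go, whether a propyl chain, a methoxy group or an amine in place of the ethyl would hold this number stays open, as does what a 4-ethylphenyl group would give.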